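Imidazolylethoxy extension carried onto the furanyl core

The compounds below may be only part of what the source reports. "The series", "measured", "known", "first", "only" and "open" are said of these compounds alone.

The series is followed in a functional assay for inhibition, with Homo sapiens as the target; on this read-out higher numbers stand for weaker inhibition and lower numbers for stronger inhibition. Compound 1 `COc1cccc(Nc2nccc(-c3ccncc3)n2)c1` gives 400 nM. Compound 2 `c1cc(Nc2nccc(-c3ccncc3)n2)cc(OCCn2ccnc2)c1` carries the change (1H-imidazol-1-yl)methyl in place of hydrogen on a saturated chain carbon bound to an oxygen on an aromatic ring and gives 200 nM; the step is a 2.0-fold lower number from compound 1 to compound 2 (0.30 log units; within the scatter). Compound 3 `COc1cccc(Nc2nccc(-c3ccco3)n2)c1` differs from compound 1 in its core by furan-2-yl in place of pyridin-4-yl on an aromatic carbon. Compound 3 gives 400 nM, so compound 1 and compound 3 stand level at the digits given, together the highest of the three numbers, and compound 2 sits a step away that stays within the scatter; the step is no change at the digits printed from compound 1 to compound 3 (within the scatter).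

Compound 4 `c1cc(Nc2nccc(-c3ccco3)n2)cc(OCCn2ccnc2)c1` has not yet been measured in this assay. It carries the change ((1H-imidazol-1-yl)methyl in place of hydrogen on a saturated chain carbon bound to an oxygen on an aromatic ring), the same change as that made between compound 1 and compound 2; it occurs twice among the compounds shown, and the place lines read the same word for word, so the change is taken as the same. Among the compounds with values here, the difference between the two cores is the one counted above between compound 1 and compound 3.

In this assay the expected step is a 2.0-fold lower number from compound 3 to compound 4 (0.30 log units; within the scatter), set beside the earlier 2.0-fold lower number from compound 1 to compound 2 (0.30 log units; within the scatter). That rests on compound 3 giving 400 nM, level with compound 1, and on the earlier step staying within the scatter, with only one measured pairing to draw on. Compound 4 is estimated at 200 nM, with a range from 100 nM to 450 nM.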

Compound 4, half-maximal inhibitory concentration: 200 nM
For compound 4 middle estimate and measured number coincide at the digits printed, within the range that was stated.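

In this assay the step from methoxy to 2-(1H-imidazol-1-yl)ethoxy on the core of compound 3 reads a 2.0-fold lower number from compound 3 to compound 4 (0.30 log units; within the scatter) and agrees with the same change on the core of compound 1: the same change on two cores in this assay, a 2.0-fold lower number (0.30 log units; within the scatter) from compound 1 to compound 2 and a 2.0-fold lower number (0.30 log units; within the scatter) from compound 3 to compound 4, 1.0-fold (0.00 log units) apart, within the scatter of two such steps. With 2-(1H-imidazol-1-yl)ethoxy in place, furan-2-yl in place of pyridin-4-yl reads no change at the digits printed from compound 2 to compound 4 (within the scatter) and agrees with the same exchange made on the methoxy compounds: the same change on two cores in this assay, no change at the digits printed (within the scatter) from compound 1 to compound 3 and no change at the digits printed (within the scatter) from compound 2 to compound 4, 1.0-fold (0.00 log units) apart, within the scatter of two such steps. Within the data shown here, the four compounds therefore show that, for these two cores, the change carries from one to the other with no sign that its step depends on the core, but every step lies within the scatter, so they do not show that the extension or the core exchange has a real effect on the read-out, nor that the agreement extends to any other core.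

Going by these compounds, it remains open whether a longer chain carrying the 1H-imidazol-1-yl group, or a simple amine or a carboxylic acid in its place, would give a step beyond the scatter in this assay. Also open, on these data alone, is whether the agreement would hold on a core bearing a phenyl group in place of furan-2-yl or pyridin-4-yl.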